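A triazole enters the chain of compound 2

A few compounds are considered here, and "the series" means these few. Any claim that something is new, unique, unknown or untested is made for them only; others in the source may bear on it.

In a functional assay on HCT-116 cells (Homo sapiens) for cytotoxicity, read by MTT assay, with a stated time of 48 h (on this read-out lower numbers stand for stronger inhibition and higher numbers for weaker inhibition), compound 1 (`COc1cc(/C=C/c2ccc(OCCCCCC(=O)NO)cc2)cc(OC)c1`) gives 4100 nM and compound 2 (`COc1cc(/C=C/c2ccc(OCCCCCCCC(=O)NO)cc2)cc(OC)c1`) gives 12600 nM as the higher of the two numbers. Compound 3 (`COc1cc(/C=C/c2ccc(OCCc3cn(CC(=O)NO)nn3)cc2)cc(OC)c1`) carries 1-((hydroxycarbamoyl)methyl)-1H-1,2,3-triazol-4-yl in place of 5-(hydroxycarbamoyl)pentyl (1-((hydroxycarbamoyl)methyl)-1H-1,2,3-triazol-4-yl in place of 5-(hydroxycarbamoyl)pentyl on a saturated chain carbon, two bonds along the chain from an oxygen on an aromatic ring). For the measured compounds named here, the one measured step that bears on this (a 3.1-fold higher number from compound 1 to compound 2 (0.49 log units; beyond the scatter)) was modest and only changed the chain length, so no measured step covers the triazole. A modest move toward a lower number is expected in this assay for this change. The estimated step (a 1.8-fold lower number from compound 2 to compound 3 (0.26 log units; within the scatter)) is expected to stay modest. Compound 3 is estimated at 7000 nM with an expected range from 2000 nM to 25000 nM in this measurement.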

Compound 3, half-maximal inhibitory concentration: 7440 nM
Compound 3: middle estimate off by 1.1-fold (0.03 log units), on the low side; the measured number falls inside the stated range.
By their numbers in this assay, from the lowest: compounds 1, 3 and 2 (each within the scatter of the next, the first and the last beyond it).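

In this assay, the triazole is accepted in the chain at this position: set against the 5-(hydroxycarbamoyl)pentyl chain the change gives a 1.7-fold lower number from compound 2 to compound 3 (0.23 log units; within the scatter), and set against the 3-(hydroxycarbamoyl)propyl chain it gives a 1.8-fold higher number from compound 1 to compound 3 (0.26 log units; within the scatter). Compound 3 thus lies within the scatter of both saturated chains, even though those two chains differ from each other beyond it. No evidence at hand explains this result. Still open, from the compounds shown here alone, is how a longer chain carrying the hydroxycarbamoyl group on the triazole would read, or a carboxylic acid in place of hydroxycarbamoyl.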